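From pyridin-4-yl to 4-methylpiperazin-1-yl on the shared core

The source may hold more compounds than are shown below. What is called first, only, known or untested is meant among the compounds shown, and "the series" means these compounds.

In a functional assay on MDA-MB-231 cells (Homo sapiens) for inhibition, read by MTT assay, with a stated time of 72 h (a lower number here means a stronger inhibitor, a higher number a weaker inhibitor), compound 1 `CC(C)(C)n1cc2c(n1)C(=O)CC1(CCN(C(=O)c3cc(-c4ccc(Cl)cc4)nc4ccccc34)CC1)O2` reaches only a limit, > 10000 nM. For the measured compounds named here, compound 2 `CC(C)(C)n1cc2c(n1)C(=O)CC1(CCN(C(=O)c3cc(-c4ccncc4)nc4ccccc34)CC1)O2` gives 1650 nM, the only actual number so far. Going by the values given here, the one measured step, an at least 6.0-fold lower number from compound 1 to compound 2 (0.78 log units; beyond the scatter), put pyridin-4-yl in place of 4-chlorophenyl on the same aromatic carbon that changes next. Compound 3 `CN1CCN(c2cc(C(=O)N3CCC4(CC3)CC(=O)c3nn(C(C)(C)C)cc3O4)c3ccccc3n2)CC1` carries 4-methylpiperazin-1-yl in place of pyridin-4-yl there: 4-methylpiperazin-1-yl in place of pyridin-4-yl on an aromatic carbon. That single step is a thin guide, so a smaller move towards a higher number is expected in this assay, a 2.1-fold higher number from compound 2 to compound 3 (0.33 log units; beyond the scatter). The estimate for compound 3 is 3500 nM, within 900 nM to 10000 nM.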

Compound 3, half-maximal inhibitory concentration: 8130 nM
Beside the measured number, compound 3's estimate is 2.3-fold (0.37 log units) below it, within the range that was stated.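

At this position on the shared core, 4-methylpiperazin-1-yl in place of pyridin-4-yl gives a weaker inhibitor in this assay, with a 4.9-fold higher number from compound 2 to compound 3 (0.69 log units; beyond the scatter). The change swaps aromatic for non-aromatic and also adds a ring nitrogen, so the step cannot separate the two. Compound 1 stands at a limit: the limit of > 10000 nM in this assay, at which 1 of the 3 values shown sits. The remaining step, an at least 1.2-fold lower number from compound 1 to compound 3 (0.08 log units; that floor lies within the scatter), is therefore only a floor and cannot be read as an order.

Which of the two differences drives the step remains open. So does how a morpholin-4-yl ring, a pyridin-3-yl ring or an open-chain dimethylamino group would fare here.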